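Fluoro for Methyl on the Anilino Ring

A few compounds are considered here, and "the series" means these few. Any claim that something is new, unique, unknown or untested is made for them only; others in the source may bear on it.

Compound 1 `COc1ccc(C(=O)c2sc(Nc3ccc(F)cc3)c(C(=O)O)c2C)cc1` and compound 2 `Cc1ccc(C(=O)c2sc(Nc3ccccc3)c(C(=O)O)c2C)cc1` share their core with compound 3 `Cc1ccc(Nc2sc(C(=O)c3ccc(C)cc3)c(C)c2C(=O)O)cc1` and with the unmeasured compound 4 `Cc1ccc(C(=O)c2sc(Nc3ccc(F)cc3)c(C(=O)O)c2C)cc1`. In a functional assay, with a stated time of 150 min, tested at 15 ug/mL (on this read-out lower numbers stand for a weaker effect and higher numbers for a stronger effect at the one concentration tested), compound 1 gives 1.98%, and in this assay compound 2 gives 1.25%; these two values lie within the scatter of each other. In this assay compound 3 was reported as "not active" (no number reported) with no number, so it has no stated position among the values shown. The change from compound 3 to compound 4 is fluoro in place of methyl on an aromatic carbon. Among the measured compounds shown here, no measured pair shows the effect of this change, and the neighbouring compounds all sit at the low end of this assay, so no step beyond the scatter is expected in either direction. Compound 4 is expected to give about 2% in this assay, with a range from 0% to 10%.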

Compound 4, a percentage reported as activity, at one concentration (the size of the read-out at that concentration, not a potency): "not active" (no number reported)
The entry for compound 4 holds no number; no gap can be computed for the estimate.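

In this assay, among the compounds shown here, compound 3 stands as "not active" (no number reported) and compound 4 as "not active" (no number reported), so no step between them can be read. As far as these compounds go, whether (4-methylphenyl)amino and (4-fluorophenyl)amino differ on this read-out stays open. Nothing shown offers an explanation for these results.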